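The source may hold more compounds than are shown below. What is called first, only, known or untested is meant among the compounds shown, and "the series" means these compounds.

Measured compounds:
- compound 1, `CC(NC(=O)c1ccc(C(=N)N)cc1)C(C)(C)C(=O)N1CCC(CC(=O)O)CC1`: 0.883 h
- compound 2, `CCC(NC(=O)c1ccc(C(=N)N)cc1)C(C)(C)C(=O)N1CCC(CC(=O)O)CC1`: 1.3 h
- compound 3, `C/C=C/C(NC(=O)c1ccc(C(=N)N)cc1)C(C)(C)C(=O)N1CCC(CC(=O)O)CC1`: 0.933 h

These three compounds share one core and were tested in an in vivo ADME assay on the whole organism (Cavia porcellus); a lower number here means that the compound disappears faster, a higher number that the compound lasts longer. Compound 1 has the lowest of the three numbers, but both neighbours sit close to it: the step of a 1.5-fold higher number from compound 1 to compound 2 (0.17 log units; within the scatter) and the step of a 1.1-fold higher number from compound 1 to compound 3 (0.02 log units; within the scatter) are each within the scatter, as is the step of a 1.4-fold lower number from compound 2 to compound 3 (0.14 log units; within the scatter). Nothing among the three, then, separates clearly from the rest.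

The unmeasured compound 4, `CC(C)CC(NC(=O)c1ccc(C(=N)N)cc1)C(C)(C)C(=O)N1CCC(CC(=O)O)CC1`, differs from compound 1 by one change: isopropyl in place of hydrogen on a saturated chain carbon, two bonds along the chain from an amide-type nitrogen. The closest comparison is the step from compound 1 to compound 2, where a methyl was added at the same place on a saturated chain carbon, two bonds along the chain from an amide-type nitrogen, and the result was a 1.5-fold higher number from compound 1 to compound 2 (0.17 log units; within the scatter). Compound 4 carries a larger group at that position, but the data give no sign that a larger addition there moves the number further. The expected outcome in this assay is therefore a step of about a 1.4-fold higher number from compound 1 to compound 4 (0.13 log units; within the scatter), that is, no change beyond the scatter. Compound 4 is estimated to give 1.2 h in this assay, with a range from 0.6 h to 2.4 h.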

Compound 4, half-life: 0.917 h
Estimate against measurement, compound 4: 1.3-fold (0.12 log units) above; measured number inside the range.
By their numbers in this assay, from the lowest: compounds 1, 4, 3 and 2 (each within the scatter of the next).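

Replacing hydrogen with isopropyl on a saturated chain carbon, two bonds along the chain from an amide-type nitrogen, is a larger addition than the methyl of compound 2, yet this assay gives only a 1.0-fold higher number from compound 1 to compound 4 (0.02 log units; within the scatter). The isobutyl of compound 4 also cannot be told apart from the other side chains at this carbon: the comparison with prop-1-en-1-yl gives a 1.0-fold lower number from compound 3 to compound 4 (0.01 log units; within the scatter), and the comparison with ethyl gives a 1.4-fold lower number from compound 2 to compound 4 (0.15 log units; within the scatter). Across methyl, ethyl, prop-1-en-1-yl and isobutyl, then, the half-life at this place stays within the scatter, and no measurement available here offers an explanation for this flat result.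

As far as these compounds go, all four groups at this carbon are plain carbon chains, so it remains open whether an amine, a hydroxyl group or a phenyl ring there would bring the half-life beyond the scatter. From the compounds shown here alone, it is also open whether a change elsewhere in the shared core, such as replacing the carboxylic acid with an ester or an amide, would do more than any change at this carbon.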